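Removing the sec-butyl side chain from a purine glycinamide ester

A few compounds are considered here, and "the series" means these few. Any claim that something is new, unique, unknown or untested is made for them only; others in the source may bear on it.

Of the compounds shown here, three have been tested in a functional assay on the whole organism (Tail, strain ICR) with Mus musculus as the target, in the tail flick test, with a stated time of 30 min, at a dose of 25 umol/kg by the oral route; a lower number here means a weaker effect, a higher number a stronger effect of the compound at the dose given. Compound 1 `CC(C)[C@H](NC(=O)CN(c1ncnc2c1ncn2C1CCCCO1)C1CC1)C(=O)OCc1ccccc1` gives 21.8%. Compound 3 `CC[C@H](C)[C@H](NC(=O)CN(c1ncnc2c1ncn2C1CCCCO1)C1CC1)C(=O)OCc1ccccc1`, which carries one more methyl on its side chain, gives 25.6%. Compound 2 `O=C(CN(c1nc(Cl)nc2[nH]cnc12)C1CC1)NCC(=O)OCc1ccccc1`, built on a different core, gives 18.7%. Compound 3 is separated from neither of the others by more than the usual scatter, so no ordering among the three can be claimed.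

Compound 4 `O=C(CN(c1ncnc2c1ncn2C1CCCCO1)C1CC1)NCC(=O)OCc1ccccc1` has not yet been measured. Its difference from compound 3 is hydrogen in place of sec-butyl on a saturated chain carbon bound to an amide-type nitrogen and a carbonyl carbon. Among the measured compounds shown here, the only measured step that bears on this change, the addition of a methyl to the side chain, gave a number 3.8 percentage points higher from compound 1 to compound 3 (within the scatter). The present change goes the other way and removes the whole side chain, so a small step downward is expected, if any, and it is not expected to pass beyond the scatter.

Compound 4 is therefore estimated at 19% in this assay, with a likely range from 9% to 29%, which means an expected step of a number 6.6 percentage points lower from compound 3 to compound 4 (within the scatter).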

Compound 4, a percentage reported as activity, at one dose (the size of the read-out at that dose, not a potency): 55.7%
Beside the measured number, compound 4's estimate is 36.7 percentage points below it; the measured number lies above the stated range.
By their numbers in this assay, from the lowest: compounds 2, 1 and 3 (each within the scatter of the next); then compound 4.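

In this assay, this saturated chain carbon proves far more sensitive than the small methyl step suggested: hydrogen in place of sec-butyl gives a large change (a number 30.1 percentage points higher from compound 3 to compound 4 (beyond the scatter)), and hydrogen in place of isopropyl gives another (a number 33.9 percentage points higher from compound 1 to compound 4 (beyond the scatter)). Isopropyl and sec-butyl could not be told apart (a number 3.8 percentage points higher from compound 1 to compound 3 (within the scatter)), yet the compound with no side chain here stands clearly apart from both, so the main contrast is between having one of these two side chains and having none. Nothing available explains this difference.

From the compounds shown here alone, at this carbon, only hydrogen, isopropyl and sec-butyl are compared, so it stays open whether a single methyl would behave more like hydrogen or more like isopropyl. Going by these compounds, it also stays open how a side chain carrying an amine or a carboxylic acid would compare.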